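The compounds below may be only part of what the source reports. "The series", "measured", "known", "first", "only" and "open" are said of these compounds alone.

Compound 1 `N[C@H]1CC[C@H](Nc2c(C(=O)NCc3ccccn3)nc(Br)c3cccnc23)CC1`: 4000 nM
Compound 2 `N[C@H]1CC[C@H](Nc2c(C(=O)NCc3ccc(F)cc3)nc(Br)c3cccnc23)CC1`: 6000 nM
Compound 3 `N[C@H]1CC[C@H](Nc2c(C(=O)NCc3cccs3)nc(Br)c3cccnc23)CC1`: 4100 nM

These three share one core and differ only in the aromatic group on a saturated chain carbon bound to an amide-type nitrogen. In a functional assay on MDA-MB-435 cells (Homo sapiens) for cytotoxicity, read by MTT assay, with a stated time of 72 h (a lower number here means a stronger inhibitor, a higher number a weaker inhibitor), compound 3 sits between the other two, but all three numbers lie close together: a 1.0-fold higher number from compound 1 to compound 3 (0.01 log units; within the scatter) and a 1.5-fold lower number from compound 2 to compound 3 (0.17 log units; within the scatter) are both within the scatter, as is a 1.5-fold higher number from compound 1 to compound 2 (0.18 log units; within the scatter). Compound 4 `CN(C)c1ccc(CNC(=O)c2nc(Br)c3cccnc3c2N[C@H]2CC[C@H](N)CC2)cc1` continues the same kind of swap: 4-(dimethylamino)phenyl in place of thiophen-2-yl on a saturated chain carbon bound to an amide-type nitrogen. Since every comparable exchange so far has left this assay essentially unchanged, no step beyond the scatter is expected, and a 1.1-fold higher number from compound 3 to compound 4 (0.04 log units; within the scatter) is the estimated change. Compound 4 is therefore expected to give about 4500 nM, with a likely range from 2000 nM to 10000 nM.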

Compound 4, half-maximal inhibitory concentration: 4000 nM
For compound 4 the middle estimate is 1.1-fold (0.05 log units) above the measured one; the range from low to high includes it.
By their numbers in this assay, from the lowest: compounds 1, 4, 3 and 2 (each within the scatter of the next).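

Swapping thiophen-2-yl (5 heavy atoms) for 4-(dimethylamino)phenyl (9 heavy atoms) on a saturated chain carbon bound to an amide-type nitrogen leaves this assay unmoved (a 1.0-fold lower number from compound 3 to compound 4 (0.01 log units; within the scatter)). The same holds for the other two comparisons (a 1.5-fold lower number from compound 2 to compound 4 (0.18 log units; within the scatter)) and (no change at the digits printed from compound 1 to compound 4 (within the scatter)), so a group with more heavy atoms and a dimethylamino substituent also stays within the scatter of the other three. No measurement shown explains this flat result.

Still open, going by these compounds, is whether a carboxylic acid, an amine or a longer chain at this place would shift the number. The effect of changes elsewhere on the shared core is open too.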